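A few compounds are considered here, and "the series" means these few. Any claim that something is new, unique, unknown or untested is made for them only; others in the source may bear on it.

Measured so far in a functional assay on MCF7 cells (Homo sapiens) for inhibition, read by MTT assay, with a stated time of 72 h; on this read-out higher numbers stand for weaker inhibition and lower numbers for stronger inhibition:

- compound 1 `CC(=O)N1CCN(c2nnc3nncn3n2)CC1`: 13900 nM
- compound 2 `c1nnc2nnc(N3CCCCC3)nn12`: 27200 nM
- compound 3 `c1nnc2nnc(N3CCCC3)nn12`: 5130 nM

All three share one core and differ in the ring amine attached to it. Compound 1 stands second highest of the three numbers. Its nearest neighbour is compound 2, whose number is higher, but that gap lies within the scatter, so nothing can be read about an order between compound 1 and compound 2. Compound 3 gives a lower number than compound 1, and that gap lies beyond the scatter, so compound 3 inhibits more strongly than compound 1 in this assay.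

Compound 4 `CC(C)COC(=O)N1CCN(c2nnc3nncn3n2)CC1` has not yet been measured in this assay. It differs from compound 1 in a single place: isobutoxy in place of methyl on a carbonyl carbon. Among the measured compounds shown here, no pair of measured compounds covers a change of this kind, so there is no measured step to lean on, and the expectation rests on where compound 1 stands at 13900 nM. The step of a 1.5-fold lower number from compound 1 to compound 4 (0.19 log units; within the scatter) is expected to be modest, at most a little beyond the scatter, with a slight lean toward a lower number. Compound 4 is therefore estimated at 9000 nM, with a range from 3000 nM to 30000 nM.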

Compound 4, half-maximal inhibitory concentration: 5390 nM
The estimate for compound 4 lay 1.7-fold (0.22 log units) above the measured number, and the stated range covers the measured number.
By their numbers in this assay, from the lowest: compounds 3 and 4 (each within the scatter of the next); then compounds 1 and 2 (each within the scatter of the next).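

In this assay, among the compounds shown here, isobutoxy in place of methyl on a carbonyl carbon gives a 2.6-fold lower number from compound 1 to compound 4 (0.41 log units; beyond the scatter), the first step that can be read for a change in a single place. This position, on a carbonyl carbon whose other neighbour is an amide-type nitrogen in a ring, therefore takes the larger isobutoxycarbonyl in place of acetyl with no loss of inhibition, and the number moves toward stronger inhibition, though the step is modest. No measurement shown here bears on the origin of this step.

The change from acetyl to isobutoxycarbonyl brings in the oxygen and the four-carbon chain together, so the compounds shown do not separate the contribution of either part, and a single pair cannot give a trend at this position. Open questions are how a shorter ethoxy, a straight butoxy, a benzyloxy, or a dimethylamino group on the same carbonyl carbon would compare with methyl and isobutoxy, and whether a plain isopentyl chain, which lacks the oxygen, would give a similar step.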